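The compounds below may be only part of what the source reports. "The series", "measured", "known", "first", "only" and "open" are said of these compounds alone.

Measured in a functional assay on MCF7 cells (Homo sapiens) for inhibition, read by MTT assay, with a stated time of 5 days; a higher number here means a weaker inhibitor, a lower number a stronger inhibitor:
- Compound 1 `Cc1cc(Nc2nc(NCc3ccc(Cl)cc3)nc3c2cnn3C2CCOCC2)n[nH]1`: 1550 nM
- Compound 2 `Cc1cc(Nc2nc(NCc3ccc(Cl)cc3)nc3c2cnn3C(C)C)n[nH]1`: 2040 nM
- Compound 3 `Cc1cc(Nc2nc(NCc3ccc(F)cc3F)nc3c2cnn3C2CCOCC2)n[nH]1`: 360 nM

Compound 3 has the lowest number of the three. Replacing 4-chlorophenyl with 2,4-difluorophenyl gives a 4.3-fold lower number from compound 1 to compound 3 (0.63 log units; beyond the scatter).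

Compound 4 `Cc1cc(Nc2nc(NCc3ccc(F)cc3F)nc3c2cnn3C(C)C)n[nH]1` differs from compound 3 by isopropyl in place of oxan-4-yl on an aromatic nitrogen. In words, this is isopropyl in place of oxan-4-yl on an aromatic nitrogen. The same exchange has been measured once, with 4-chlorophenyl present, and gave a 1.3-fold higher number from compound 1 to compound 2 (0.12 log units; within the scatter). The step to the 2,4-difluorophenyl group sets the starting level of compound 3 but does not measure the exchange itself. Among the measured compounds shown here, no measured pair tests the exchange with 2,4-difluorophenyl present, so carrying the single measured step over to it is an assumption.

No step beyond the scatter is therefore expected in this assay, with at most a small drift toward a higher number. The estimated change is a 1.3-fold higher number from compound 3 to compound 4 (0.10 log units; within the scatter). Compound 4 is expected at 450 nM, with an estimated range of 220 nM to 900 nM.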

Compound 4, half-maximal inhibitory concentration: 4320 nM
The estimate for compound 4 lay 9.6-fold (0.98 log units) below the measured number; the measured number lies above the stated range.
By their numbers in this assay, from the lowest: compound 3; then compounds 1 and 2 (each within the scatter of the next); then compound 4.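

On the aromatic nitrogen, isopropyl in place of oxan-4-yl is not a neutral exchange in this assay: with 2,4-difluorophenyl present it gives a 12-fold higher number from compound 3 to compound 4 (1.08 log units; beyond the scatter), so its size depends on the aryl group elsewhere in the molecule: the same change on two cores in this assay, a 1.3-fold higher number (0.12 log units; within the scatter) from compound 1 to compound 2 and a 12-fold higher number (1.08 log units; beyond the scatter) from compound 3 to compound 4, 9.1-fold (0.96 log units) apart, beyond the scatter of two such steps The dependence also shows from the other side, where 2,4-difluorophenyl in place of 4-chlorophenyl gives a 2.1-fold higher number from compound 2 to compound 4 (0.33 log units; beyond the scatter) with isopropyl present, opposite in direction to the same change with oxan-4-yl present: the same change on two cores in this assay, a 4.3-fold lower number (0.63 log units; beyond the scatter) from compound 1 to compound 3 and a 2.1-fold higher number (0.33 log units; beyond the scatter) from compound 2 to compound 4, 9.1-fold (0.96 log units) apart, beyond the scatter of two such steps The two places therefore do not act independently in these four compounds, and the advantage of 2,4-difluorophenyl appears only with oxan-4-yl.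

Open, on these data alone, is whether the difference follows the ring of oxan-4-yl or its oxygen; a cyclohexyl group with 2,4-difluorophenyl present would separate the two. Also open, as far as these compounds go, is which fluorine matters, which a 4-fluorophenyl or 2-fluorophenyl group would address on either side of the exchange.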